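The compounds below may be only part of what the source reports. "The series", "measured", "known", "first", "only" and "open" are said of these compounds alone.

Measured compounds:
- Compound 1, `Cn1c(COc2cccc(C(=O)O)c2)nc2ccc(Oc3ccc4c(c3)OCC4)nc21`, gives 9.1 10^-6 cm/s in an ADME assay for permeability, using PAMPA, with a stated time of 4 h; on this read-out lower numbers stand for lower permeability and higher numbers for higher permeability.
- Compound 2, `Cn1c(COc2cccc(C(=O)O)c2)nc2ccc(Oc3ccc(Cl)cn3)cc21`, gives 16.2 10^-6 cm/s in this assay.

Only these two numbers exist so far, and they sit within the usual scatter of each other, so neither compound can be said to pass the membrane better than the other; compound 2 simply stands alongside compound 1 on this read-out. Compound 3, `Cn1c(COc2cccc(C(=O)O)c2)nc2ccc(Oc3ccc(F)cn3)cc21`, has not yet been measured. It differs from compound 2 in a single place: fluoro in place of chloro on an aromatic carbon. Both halogens are single heavy atoms without donors or acceptors and without charge, so the change is about as small as a change on an aromatic carbon can be. For the measured compounds named here, no measured pair in this set shows what such a swap does in this assay, so the expectation rests only on the closeness of compound 1 and compound 2 and on the size of the change. The step from compound 2 to compound 3 is expected to be a 1.2-fold lower number from compound 2 to compound 3 (0.10 log units; within the scatter), that is, nothing beyond the scatter. Compound 3 is therefore estimated at 13 10^-6 cm/s, with a likely range from 7 10^-6 cm/s to 24 10^-6 cm/s.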

Compound 3, apparent permeability: 4.7 10^-6 cm/s
For compound 3 the middle estimate is 2.8-fold (0.44 log units) above the measured one, outside the stated range (below it).
By their numbers in this assay, from the lowest: compounds 3, 1 and 2 (each within the scatter of the next, the first and the last beyond it).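

In this assay, fluoro in place of chloro at this position gives a 3.4-fold lower number from compound 2 to compound 3 (0.54 log units; beyond the scatter). Compounds 1 and 2 differ in more than one place, so they could not isolate any single change, whereas this pair shows that the number can move beyond the scatter when a single heavy atom is exchanged on an aromatic carbon, two atoms from the ring nitrogen, with the counts of hydrogen-bond donors and acceptors and the net charge unchanged. The compounds shown offer no independent measurement that explains this step.

With only chloro and fluoro shown here, it remains open where a methyl, methoxy, nitrile or trifluoromethyl group at the same position would fall relative to compound 2 and compound 3. From the compounds shown here alone, it also remains open whether the same exchange of chloro for fluoro would give a step of similar size on a different scaffold, or whether this result holds only for the 5-chloropyridin-2-yl and 5-fluoropyridin-2-yl pair on this core.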